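The source may report more compounds than this note shows. Statements on the series, on what has been measured and on what is new or still open speak of the compounds shown alone.

Of the compounds shown here, three have been measured in a functional assay for inhibition of Polyunsaturated fatty acid 5-lipoxygenase (Homo sapiens); a higher number here means a weaker inhibitor, a lower number a stronger inhibitor. Compound 1 `O=C(O)/C=N/OC(c1ccc(OCc2nc3cccnc3s2)cc1)C1CCCCC1` gives 27 nM, the lowest number of the three. Compound 3 `C/C(=N\OC(c1ccc(OCc2nc3ccccc3s2)cc1)C1CCCCC1)C(=O)O` gives 60 nM, and compound 2 `C/C(=N\OC(c1ccc(OCc2cscn2)cc1)C1CCCCC1)C(=O)O` gives 360 nM. Compounds 2 and 3 share the same acid-bearing oxime portion and differ only in the ring attached on a saturated chain carbon bound to an oxygen on an aromatic ring: 1,3-benzothiazol-2-yl in compound 3 in place of 1,3-thiazol-4-yl in compound 2, which brought a 6.0-fold lower number from compound 2 to compound 3 (0.78 log units; beyond the scatter). Compound 1 carries a different bicyclic ring at the same position and a shorter oxime portion, so its standing against the other two is shown only by the values themselves.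

Compound 4 `O=C(O)/C=N/OC(c1ccc(OCc2nc3ccccc3o2)cc1)C1CCCCC1` keeps everything in compound 1 except that position, where (a group of 9 heavy atoms (7 carbon, 1 nitrogen, 1 oxygen; one five-membered aromatic ring with 2 hetero atoms, one six-membered aromatic ring of carbon only) in place of a group of 9 heavy atoms (6 carbon, 2 nitrogen, 1 sulfur; one five-membered aromatic ring with 2 hetero atoms, one six-membered aromatic ring with 1 hetero atom), on a saturated chain carbon bound to an oxygen on an aromatic ring). Among the measured compounds shown here, no measured step swaps one bicyclic ring for another of the same size; the only step at this position, from compound 2 to compound 3, grew the ring by a fused six-membered ring rather than exchanging heteroatoms. The two rings in compound 1 and compound 4 are the same size and shape, so only a small step is expected, a 1.7-fold higher number from compound 1 to compound 4 (0.22 log units; within the scatter), in this assay. Compound 4 is therefore estimated at 45 nM, likely between 15 nM and 140 nM.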

Compound 4, half-maximal inhibitory concentration: 143 nM
Estimate against measurement, compound 4: 3.2-fold (0.50 log units) below; measured number above the stated range.
By their numbers in this assay, from the lowest: compound 1; then compound 3; then compound 4; then compound 2.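

Two rings with the same heavy-atom count and the same ring sizes are not interchangeable at this position: in this assay, the exchange for 1,3-benzoxazol-2-yl brought a 5.3-fold higher number from compound 1 to compound 4 (0.72 log units; beyond the scatter). Among the compounds shown here, the only earlier step here, a 6.0-fold lower number from compound 2 to compound 3 (0.78 log units; beyond the scatter), came with a larger ring, whereas this one shows that the number can also move when size stays the same and only the make-up of the rings changes. No measurement shown here accounts for the change in this position.

Two things change together in this exchange, since the six-membered ring becomes carbon only and the five-membered ring takes an oxygen in place of a sulfur, so the compounds shown leave open which of the two matters, and a single change on the core of compound 1 would be needed to separate them. Also open, on these data alone, is how other rings of this kind would behave at the same place on that core, such as 1H-benzimidazol-2-yl, which carries a ring nitrogen with a hydrogen where compound 4 has its oxygen.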